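The source may hold more compounds than are shown below. What is called first, only, known or untested is meant among the compounds shown, and "the series" means these compounds.

In a functional assay on HOP-62 cells (Homo sapiens) for inhibition, read by sulforhodamine B assay, with a stated time of 48 h, tested at 10 uM (a higher number here means a weaker effect of the compound at the concentration tested, a lower number a stronger effect), compound 1 `COc1cc2cc(Oc3ccc(NC(=O)Nc4ccccc4)cc3)c(C)nc2cc1OC` gives 103%, compound 2 `COc1cc2cc(Oc3ccc(NC(=O)Nc4ccc(C(F)(F)F)cc4)cc3)c(C)nc2cc1OC` gives 18.8%, and compound 3 `COc1cc2cc(Oc3ccc(NC(=O)Nc4cccc(C(F)(F)F)c4)cc3)c(C)nc2cc1OC` gives 25%. Compound 3 stands second highest of the three numbers: it sits within the scatter of compound 2, since a number 6.2 percentage points higher from compound 2 to compound 3 (within the scatter), while a number 78 percentage points lower from compound 1 to compound 3 (beyond the scatter) and, alike, a number 84.2 percentage points lower from compound 1 to compound 2 (beyond the scatter) are both large. Compound 4 `COc1cc2cc(Oc3ccc(NC(=O)Nc4ccc(Cl)c(Cl)c4)cc3)c(C)nc2cc1OC` differs from compound 3 by 3,4-dichlorophenyl in place of 3-(trifluoromethyl)phenyl on an amide-type nitrogen. Within the data shown here, no measured step swaps trifluoromethyl for two chlorines, so only the two large steps away from compound 1 bear on it, and they suggest compound 4 will also stay far from compound 1. Compound 4 is therefore expected to show no change at the digits printed from compound 3 to compound 4 (within the scatter), with an estimate of 25% in this assay, ranging from 5% to 60%.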

Compound 4, a percentage reported as activity, at one concentration (the size of the read-out at that concentration, not a potency): 55.2%
The estimate for compound 4 lay 30.2 percentage points below the measured number; the range from low to high includes it.
By their numbers in this assay, from the lowest: compounds 2 and 3 (each within the scatter of the next); then compound 4; then compound 1.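

On this amide-type nitrogen, the ring substituents are not interchangeable in this assay: 3,4-dichlorophenyl gives a weaker effect than either trifluoromethyl-bearing ring (a number 30.2 percentage points higher from compound 3 to compound 4 (beyond the scatter); a number 36.4 percentage points higher from compound 2 to compound 4 (beyond the scatter)). It still gives a stronger effect than plain phenyl (a number 47.8 percentage points lower from compound 1 to compound 4 (beyond the scatter)), so this change lands in a middle band rather than at either end. No measurement here explains why the two chlorines differ from trifluoromethyl. Open, from the compounds shown here alone, is how a single chlorine, a methoxy group or a nitrile on this ring would read.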